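This account rests on a few compounds, and the source may have more. Where it says the series, first, only, none or still open, it means among the compounds named here.

Working notes on the series.

Compound 1 `C=C1[C@@H](OC(C)=O)C[C@@H]2[C@](C)(CO[Si](C)(C)C(C)(C)C)[C@H](OC(C)=O)CC[C@@]2(C)[C@@H]1C[C@@H](Nc1ccccc1F)C1=CCOC1=O` is the reference point. In a functional assay on A549 cells (Homo sapiens) for cytotoxicity, read by sulforhodamine B assay (a higher number here means a weaker inhibitor, a lower number a stronger inhibitor), compound 1 gives 3190 nM, the lowest of the two numbers recorded so far. For the measured compounds named here, the only other measured compound, compound 2 `C=C1[C@@H](OC(C)=O)C[C@@H]2[C@](C)(COC=O)[C@H](OC(C)=O)CC[C@@]2(C)[C@@H]1C[C@@H](Nc1cccc2ccccc12)C1=CCOC1=O`, carries a different group on the amine nitrogen and a different ester on the shared core, so it is not a single-change neighbour of compound 1; in this assay compound 2 gives 35600 nM, a markedly higher number that lies beyond the scatter of repeated measurements. Compound 1 therefore stands as the stronger of the two, with nothing closer to compare it against.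

The next compound, compound 3 `C=C1[C@@H](OC(C)=O)C[C@@H]2[C@](C)(CO[Si](C)(C)C(C)(C)C)[C@H](OC(C)=O)CC[C@@]2(C)[C@@H]1C[C@@H](Nc1ccc(F)cc1)C1=CCOC1=O`, differs from compound 1 only on the amine nitrogen: 4-fluorophenyl in place of 2-fluorophenyl on an amine nitrogen. Going by the values given here, no measured pair in the set shows what moving the fluorine around the aromatic ring does, so the direction of the step is not anchored by data. With the same atoms simply joined differently, the step in this assay is estimated to be small, close to the scatter and with no confident sign: a 1.1-fold higher number from compound 1 to compound 3 (0.04 log units; within the scatter). Compound 3 is expected to give 3500 nM in this assay, within a range estimated at 1200 nM to 10000 nM.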

Compound 3, half-maximal inhibitory concentration: 4550 nM
For compound 3 the middle estimate is 1.3-fold (0.11 log units) below the measured one; measured number inside the range.
By their numbers in this assay, from the lowest: compounds 1 and 3 (each within the scatter of the next); then compound 2.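

In this assay, for the compounds shown here, the exchange of 2-fluorophenyl for 4-fluorophenyl on the amine nitrogen gives a 1.4-fold higher number from compound 1 to compound 3 (0.15 log units; within the scatter) and provides the first single-change pair. For this pair, the two placements of fluorine named in these groups read alike, so the measured difference offers no basis for preferring either one on the shared core. No independent measurement bears on the reason for this result.

As far as these compounds go, whether an unsubstituted phenyl, a 4-chlorophenyl or a 4-methoxyphenyl on the same amine nitrogen would also stay within the scatter remains open, so the reach of this finding beyond the two fluorophenyl groups is unknown. Compound 2, at 35600 nM, still differs from compound 1 and compound 3 in more than one place, so its value cannot be assigned to either the group on the amine nitrogen or the ester on the core, and those contributions cannot yet be read separately.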